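Quinolin-2-yl amide replaces methoxyphenyl amide on shared core

This account rests on a few compounds, and the source may have more. Where it says the series, first, only, none or still open, it means among the compounds named here.

Measured compounds:
Compound 1 `CN1[C@@H]2c3[nH]c4ccccc4c3C[C@H]1[C@H](C#N)N1[C@@H](CN3C(=O)c4ccccc4C3=O)c3[nH]c4ccccc4c3C[C@@H]21` gives 80 nM in a functional assay on HT-29 cells (Homo sapiens) for cytotoxicity, read by MTT assay, with a stated time of 72 h; on this read-out lower numbers stand for stronger inhibition and higher numbers for weaker inhibition.
Compound 2 `COc1ccc(C(=O)NC[C@H]2c3[nH]c4ccccc4c3C[C@H]3[C@H]4c5[nH]c6ccccc6c5C[C@@H]([C@H](C#N)N23)N4C)cc1` gives 840 nM in this assay.

Compound 2 stands highest of the two numbers in this assay; its nearest neighbour is compound 1, and that step is an 11-fold higher number from compound 1 to compound 2 (1.02 log units; beyond the scatter). Compound 3 `CN1[C@@H]2c3[nH]c4ccccc4c3C[C@H]1[C@H](C#N)N1[C@@H](CNC(=O)c3ccc4ccccc4n3)c3[nH]c4ccccc4c3C[C@@H]21` is not yet measured. It differs from compound 2 by quinolin-2-yl in place of 4-methoxyphenyl on a carbonyl carbon. Going by the values given here, the only measured step, from compound 1 to compound 2, concerns a different exchange at the same part of the core, so it says nothing direct about this change, and no measured pair bears on it. Both amides keep the same carbonyl and amide nitrogen, so no large step is expected in this assay. Compound 3 is expected to show a 2.1-fold lower number from compound 2 to compound 3 (0.32 log units; beyond the scatter) in this assay. The estimate for compound 3 is 400 nM, within 100 nM to 1600 nM.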

Compound 3, half-maximal inhibitory concentration: 150 nM
Estimate against measurement, compound 3: 2.7-fold (0.43 log units) above; the measured number falls inside the stated range.
By their numbers in this assay, from the lowest: compounds 1 and 3 (each within the scatter of the next); then compound 2.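

In this assay, exchanging 4-methoxyphenyl for quinolin-2-yl on the carbonyl carbon gives a 5.6-fold lower number from compound 2 to compound 3 (0.75 log units; beyond the scatter), which shows that the number responds to the group on the carbonyl even when the amide itself stays in place. Compound 1 and compound 3 lie within the scatter of each other, so the higher number of compound 2 is not shared by every amide at this position, as the earlier step alone could not show. Nothing available explains this difference between the two amides.

The compounds shown leave open whether the lower number of compound 3 goes with its ring nitrogen or with its second ring. A pyridin-2-yl or a naphthalen-2-yl on the same carbonyl carbon would separate these two features.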